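Notes on the xanthine series at the A2b receptor

This account rests on a few compounds, and the source may have more. Where it says the series, first, only, none or still open, it means among the compounds named here.

Measured compounds:
compound 1 `CCCn1c(=O)c2[nH]c(-c3ccccc3)nc2n(CCSCC)c1=O` — 191 nM
compound 2 `CCn1c(=O)c2c(nc(Cc3cccs3)n2C)n(Cc2ccccc2)c1=O` — 372 nM
compound 3 `CCn1c(=O)c2c(nc(Cc3ccco3)n2C)n(Cc2ccccc2)c1=O` — 282 nM

In an assay on HEK293 cells for displacement of a labelled ligand from adenosine receptor A2b (Homo sapiens), read by scintillation counting (on this read-out lower numbers stand for stronger inhibition and higher numbers for weaker inhibition), compound 2 gives 372 nM, the highest of the three numbers, but its gaps to the other two are within the scatter: the step of a 1.3-fold lower number from compound 2 to compound 3 (0.12 log units; within the scatter), and compound 1 with 191 nM sits within the scatter of compound 2 as well. No ordering among the three can be claimed.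

Compound 4 `CCn1c(=O)c2c(nc(Cc3cccs3)n2C)n(Cc2cccs2)c1=O` is not yet measured. From compound 2 it differs in one place: thiophen-2-yl in place of phenyl on a saturated chain carbon bound to an aromatic nitrogen. Within the data shown here, the only measured step, a 1.3-fold lower number from compound 2 to compound 3 (0.12 log units; within the scatter), concerns an exchange of one five-membered ring for another at the other saturated chain carbon, the one bound to an aromatic carbon, and it was within the scatter. Among the measured compounds shown here, no measured pair shows a change of the group on the carbon bound to the aromatic nitrogen, so the present change is not covered directly. What the data do show is that swapping aromatic rings elsewhere on this core left the number unchanged beyond the scatter; on that basis no step beyond the scatter is expected in this assay, and the estimate is a 1.2-fold lower number from compound 2 to compound 4 (0.07 log units; within the scatter).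

The expected value for compound 4 in this assay is 320 nM, with a range from 150 nM to 700 nM.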

Compound 4, inhibition constant: 35.5 nM
Compound 4: the middle estimate sits 9.0-fold (0.95 log units) above what was measured; measured number below the stated range.
By their numbers in this assay, from the lowest: compound 4; then compounds 1, 3 and 2 (each within the scatter of the next).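

In this assay, among these compounds, the group on the saturated chain carbon bound to an aromatic nitrogen proves to be a sensitive point on the shared core: thiophen-2-yl in place of phenyl gives a 10-fold lower number from compound 2 to compound 4 (1.02 log units; beyond the scatter) and is the only step beyond the scatter. The exchange at the saturated chain carbon bound to an aromatic carbon, a 1.3-fold lower number from compound 2 to compound 3 (0.12 log units; within the scatter) and within the scatter, showed no such sensitivity, although that step swaps one five-membered ring for another while the new step replaces a six-membered aromatic ring of carbon only with a five-membered ring holding one hetero atom, so place and type of exchange cannot be separated. Nothing at hand explains the size of the new step.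

Going by these compounds, it remains open whether the step follows the sulfur atom, the ring size or the hydrogen-bond acceptor counted on thiophen-2-yl, a question that furan-2-yl, pyridin-2-yl or cyclopentyl on the same carbon would address. Also open, on these data alone, is whether a longer chain between this ring and the aromatic nitrogen keeps the step, and whether it persists with furan-2-yl on the other chain carbon.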